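Removing the nitrile from the ring on the amine nitrogen

The compounds below may be only part of what the source reports. "The series", "measured", "known", "first", "only" and "open" are said of these compounds alone.

Compound 3 `CC(C)(C)c1ccc(NC(=O)C2=CCN(c3ncccc3C#N)CC2)cc1` was tested in an in vitro functional assay on 1321-N1 cells for antagonist activity at transient receptor potential cation channel subfamily V member 1 (Homo sapiens), read by FLIPR and calcium flux (a lower number here means a stronger inhibitor, a higher number a weaker inhibitor), and gives 78 nM. Compound 2 `O=C(Nc1ccc(Cl)c(F)c1)C1=CCN(c2ncccc2Cl)CC1` gives 78 nM, level with compound 3 at the digits shown. Compound 1 `O=C(Nc1ccc(C(F)(F)F)nc1)C1=CCN(c2ncccc2C(F)(F)F)CC1` gives 42 nM, a value that stays within the usual scatter of compound 3, so none of the three can be ranked against the others. Compound 4 `CC(C)(C)c1ccc(NC(=O)C2=CCN(c3ncccn3)CC2)cc1` has not been measured and differs from compound 3 in one place: pyrimidin-2-yl in place of 3-cyanopyridin-2-yl on an amine nitrogen in a ring. Among the measured compounds shown here, no pair of measured compounds shows this change, so the expectation rests on the change alone. In this assay compound 4 is expected to give a higher number, with the step of a 7.7-fold higher number from compound 3 to compound 4 (0.89 log units; beyond the scatter) expected to lie beyond the scatter. Compound 4 is therefore estimated at 600 nM, with a range from 150 nM to 3000 nM.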

Compound 4, half-maximal inhibitory concentration: 10 nM
For compound 4 the middle estimate is 60-fold (1.78 log units) above the measured one; the whole stated range lies above it.
By their numbers in this assay, from the lowest: compound 4; then compounds 1, 2 and 3 (each within the scatter of the next).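

In this assay, the position on the amine nitrogen in a ring keeps its activity without the nitrile: pyrimidin-2-yl in place of 3-cyanopyridin-2-yl gives a 7.8-fold lower number from compound 3 to compound 4 (0.89 log units; beyond the scatter) and the change is a gain. Among the compounds shown here, this is the only step at this position that can be read, and it shows that 3-cyanopyridin-2-yl is not required here. No measurement at hand accounts for this gain.

From the compounds shown here alone, the change removes the nitrile and adds a ring nitrogen at once, so the share of each remains open. A plain pyridin-2-yl would separate the two, and an amine on the pyrimidin-2-yl would test how much room for change this position allows.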